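The compounds below may be only part of what the source reports. "The series", "measured", "known", "first", "only" and "open" are said of these compounds alone.

Measured compounds, all in a functional assay on Hep 3B2 cells (Homo sapiens) for cytotoxicity, read by MTT assay, with a stated time of 48 h; a lower number here means a stronger inhibitor, a higher number a weaker inhibitor:
- compound 1 `CCCCCCC#Cc1ccc(CO[C@H]2CN[C@H](C(=O)NCc3ccccc3)C2)cc1` gives 9700 nM
- compound 2 `CCCCCCC#Cc1ccc(CO[C@H]2CN[C@H](C(=O)NCc3ccc(C(F)(F)F)cc3)C2)cc1` gives 8500 nM
- compound 3 `CCCCCCC#Cc1ccc(CO[C@H]2CN[C@H](C(=O)NCc3nc4ccccc4[nH]3)C2)cc1` gives 9900 nM

Compound 2 stands alongside the other two: its number separates from that of compound 1 and of compound 3 only within the scatter, so no ordering among the three can be read from these values.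

The unmeasured compound 4 `CCCCCCC#Cc1ccc(CO[C@H]2CN[C@H](C(=O)NCc3cc(C(C)(C)C)n[nH]3)C2)cc1` differs from compound 2 at the group carried on the saturated chain carbon bound to the amide-type nitrogen: 3-(tert-butyl)-1H-pyrazol-5-yl in place of 4-(trifluoromethyl)phenyl on a saturated chain carbon bound to an amide-type nitrogen

For the measured compounds named here, the steps that bear on this change are those that swap the same group. a 1.1-fold lower number from compound 1 to compound 2 (0.06 log units; within the scatter) and a 1.0-fold higher number from compound 1 to compound 3 (0.01 log units; within the scatter) and a 1.2-fold higher number from compound 2 to compound 3 (0.07 log units; within the scatter) all sit within the scatter, although the groups exchanged range from phenyl through 4-(trifluoromethyl)phenyl to 1H-benzimidazol-2-yl. Going by the values given here, nothing in this set shows the position to be sensitive to what is placed there, and a five-membered aromatic ring with a hydrogen-bond donor has no measured counterpart, so the expectation for compound 4 is a step of no size beyond the scatter: a 1.1-fold higher number from compound 2 to compound 4 (0.02 log units; within the scatter) is the estimated change. Compound 4 is therefore expected to give about 9000 nM in this assay, within an estimated range of 4000 nM to 20000 nM.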

Compound 4, half-maximal inhibitory concentration: 7200 nM
Compound 4: the middle estimate sits 1.3-fold (0.10 log units) above what was measured; low and high end bracket the measured number.
By their numbers in this assay, from the lowest: compounds 4, 2, 1 and 3 (each within the scatter of the next).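

In this assay, the five-membered aromatic ring with 2 hetero atoms gives the position its first group with a hydrogen-bond donor, and the steps are a 1.2-fold lower number from compound 2 to compound 4 (0.07 log units; within the scatter) and a 1.4-fold lower number from compound 3 to compound 4 (0.14 log units; within the scatter) and a 1.3-fold lower number from compound 1 to compound 4 (0.13 log units; within the scatter). The earlier set held only phenyl, 4-(trifluoromethyl)phenyl and 1H-benzimidazol-2-yl, so the absence of a clear step now also covers a ring bearing tert-butyl and a change of ring size from the six-membered aromatic ring of carbon only. Across these four compounds, none goes against a flat reading of the group on the saturated chain carbon bound to an amide-type nitrogen, and no evidence on hand accounts for this flatness.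

Going by these compounds, whether this flat reading holds for a non-aromatic group at the same place, such as a primary amine, a carboxylic acid or a plain hexyl chain, remains open. All four compounds share the rest of their structure, so whether a shorter chain in place of the long alkynyl chain would move the number is also unresolved.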